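The source may hold more compounds than are shown below. What is called first, only, known or untested is meant among the compounds shown, and "the series" means these compounds.

Compound 1 `COc1cc(/C=C(/Sc2ccc(Br)cc2)C(=O)c2ccc(Br)cc2)ccc1O` has been measured in a functional assay on DU-145 cells (Homo sapiens) for inhibition, read by trypan blue exclusion, with a stated time of 96 h (a higher number here means a weaker inhibitor of growth, a lower number a stronger inhibitor of growth), where compound 1 gives 1000 nM. Two further compounds have values in this assay. Compound 3 `O=C(/C(=C\c1ccc(O)c([N+](=O)[O-])c1)Sc1ccc(Br)cc1)c1ccc(Br)cc1` gives 1000 nM, and the step of no change at the digits printed from compound 1 to compound 3 (within the scatter) stays within the scatter. Compound 2 `Cc1ccc(C(=O)/C(=C\c2ccc(N(C)C)cc2)S(=O)(=O)c2ccc(Cl)cc2)cc1` gives 50000 nM; compound 2 differs from compound 1 in more than one place, so its value can only be set beside that of compound 1 without a single step being drawn. On these numbers compound 1 stands level with compound 3, the two together holding the lowest numbers, while compound 2 lies furthest away with a far higher number.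

Compound 4 `O=C(/C(=C\c1ccc(Br)c(O)c1)Sc1ccc(Br)cc1)c1ccc(Br)cc1` has not yet been measured in this assay. Its difference from compound 1 is 4-bromo-3-hydroxyphenyl in place of 4-hydroxy-3-methoxyphenyl on a double-bonded chain carbon bound to a double-bonded chain carbon. Among the compounds with values here, only one measured step bears on this change: no change at the digits printed from compound 1 to compound 3 (within the scatter) exchanged a substituent on this same ring, nitro in place of methoxy on an aromatic carbon, and produced no change within the scatter. The move to compound 4 again alters only the substituents of this ring, keeping 1 hydrogen-bond donor. The expectation is therefore a step of no change at the digits printed from compound 1 to compound 4 (within the scatter) that does not go beyond the scatter. Compound 4 is estimated at 1000 nM, with a range from 400 nM to 2500 nM.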

Compound 4, concentration for 50% growth inhibition: 1000 nM
Compound 4: the middle estimate sits on the measured number at the digits printed, and the stated range covers the measured number.
By their numbers in this assay, from the lowest: compounds 1, 3 and 4 (each within the scatter of the next); then compound 2.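

In this assay the step is no change at the digits printed from compound 1 to compound 4 (within the scatter), and here the whole 4-hydroxy-3-methoxyphenyl gives way to 4-bromo-3-hydroxyphenyl, whereas the earlier step of no change at the digits printed from compound 1 to compound 3 (within the scatter) exchanged only the methoxy for a nitro and left the hydroxy in its place. The number therefore holds within the scatter even when the hydroxy stands at a different place on this ring, the methoxy is gone, a bromine enters, and the count goes from 2 hydrogen-bond acceptors to 1 hydrogen-bond acceptor, so in these compounds the 4-hydroxy-3-methoxyphenyl pattern is not needed to keep this level. No measurement shown accounts for why these exchanges leave the number in place.

From the compounds shown here alone, all the compounds compared on this ring still carry 1 hydrogen-bond donor there, so it stays open whether a plain phenyl, with no hydroxy at all, would hold the same level. Going by these compounds, it is equally open whether a carboxylic acid on this ring would go beyond the scatter, and whether the flat result would persist on a core that differs from that of compound 1.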